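The source may hold more compounds than are shown below. What is called first, only, known or untested is meant among the compounds shown, and "the series" means these compounds.

Three compounds were tested in a functional assay on M14 cells (Homo sapiens) for cytotoxicity, read by sulforhodamine B assay, with a stated time of 48 h; a lower number here means that less compound is tolerated, a higher number that more compound is tolerated. Compound 1 `ClCc1ccc(Cn2cnc3c(Cl)ncnc32)cc1` gives 9120 nM in this assay, compound 2 `ClCc1cccc(Cn2cnc3c(Cl)nc(Cl)nc32)c1` gives 6450 nM, and compound 3 `ClCc1ccccc1Cn1cnc2ncnc(Cl)c21` gives 27500 nM. Among these three numbers compound 3 stands highest: the nearest of the others is compound 1, already beyond the scatter, and compound 2 lies further away still. Compound 1 and compound 2 each differ from compound 3 in more than one place, so neither gap can be read as a single step.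

Compound 4 `ClCc1ccccc1Cn1cnc2nc(Cl)nc(Cl)c21` differs from compound 3 by chloro in place of hydrogen on an aromatic carbon. Within the data shown here, no measured pair shows this change alone. Compound 2, which also carries two chloro groups on the core, sits beyond the scatter below compound 3, but its benzyl substitution pattern differs as well, so it cannot settle the matter on its own. The step is therefore expected to run downward by a modest amount, close to the edge of the scatter, a 1.8-fold lower number from compound 3 to compound 4 (0.26 log units; within the scatter). Compound 4 is accordingly estimated at 15000 nM, with a range from 5000 nM to 40000 nM.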

Compound 4, concentration lethal to 50% of the cells: 6450 nM
Compound 4: middle estimate off by 2.3-fold (0.37 log units), on the high side, and the stated range covers the measured number.
By their numbers in this assay, from the lowest: compounds 2, 4 and 1 (each within the scatter of the next); then compound 3.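

Chloro in place of hydrogen on an aromatic carbon, at the place between two ring nitrogen atoms, brings a 4.3-fold lower number from compound 3 to compound 4 (0.63 log units; beyond the scatter) in this assay, and this is the first single-place step in the set, since the earlier gaps each mixed more than one difference. It shows that this position is not indifferent to substitution: one added chlorine atom, with the rest of compound 3 unchanged, moves the number beyond the scatter, toward less compound being tolerated. Nothing at hand accounts for the size or direction of this step.

What the compounds shown leave open is whether a different group at this place, such as an amine, a methoxy group or a fluoro group, would move the number the same way as chloro does. Among these compounds, also open is whether the chloro step carries over when the chloromethyl group stands elsewhere on the benzyl portion, as in compound 1 and compound 2, since those two differ from each other in more than one place and offer no matching pair.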